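The compounds below may be only part of what the source reports. "The series", "measured", "known", "first", "only" and "open" are said of these compounds alone.

Measured so far in a functional assay on MKN-45 cells (Homo sapiens) for inhibition, with a stated time of 72 h; on this read-out higher numbers stand for weaker inhibition and lower numbers for stronger inhibition:
- Compound 1 `COc1cc(C(=O)c2cccc3[nH]ccc23)cc(OC)c1OC`: 49.1 nM
- Compound 2 `COc1cc(C(=O)c2cccc3cc[nH]c23)cc(OC)c1OC`: 210 nM

Compound 1 has the lower of these two numbers, which makes it the stronger inhibitor of the pair. Compound 2 has the higher number at 210 nM, and the gap between them lies beyond the usual scatter of repeated measurements.

The next compound to be tested is compound 3 `COc1cc(C(=O)c2cccc3c2ccn3C)cc(OC)c1OC`. It keeps the core of compound 1 and carries methyl in place of hydrogen on an aromatic nitrogen.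

Within the data shown here, neither of the measured compounds carries this methyl, so the data show no step of this kind to learn from. Among the measured compounds shown here, the only guide is the starting point, compound 1 at 49.1 nM, and the change itself is a single added carbon. With nothing pointing firmly either way, the expectation in this assay is no step beyond the scatter, with a slight lean towards a higher number. The expected step, a 1.2-fold higher number from compound 1 to compound 3 (0.09 log units; within the scatter), is therefore small, though an uncertain estimate. For compound 3 the estimated value is 60 nM, with an expected range from 15 nM to 250 nM.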

Compound 3, half-maximal inhibitory concentration: 21.6 nM
Estimate against measurement, compound 3: 2.8-fold (0.44 log units) above; the range from low to high includes it.
By their numbers in this assay, from the lowest: compound 3; then compound 1; then compound 2.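

In this assay, putting methyl in place of hydrogen on the aromatic nitrogen gives a 2.3-fold lower number from compound 1 to compound 3 (0.36 log units; beyond the scatter), a modest step but one that lies beyond the usual scatter of repeated measurements. Among these compounds, this is the first look at this position, and it shows that the hydrogen on this nitrogen is not needed for inhibition in this pair: once it is replaced, the number falls rather than rises. The position therefore accepts a single added carbon without any loss, and with a measurable gain, although nothing measured here says why the methyl has this effect.

From the compounds shown here alone, one methyl says little about how far this trend runs, so it remains open whether an ethyl group, a longer chain, or a chain ending in an amine or a carboxylic acid on the same nitrogen would extend the gain or reverse it. Going by these compounds, it is also open whether methyl on the nitrogen of compound 2 would produce a step of similar size, or whether this gain belongs to the core of compound 1 alone.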